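The source may hold more compounds than are shown below. What is called first, only, known or untested is meant among the compounds shown, and "the series" means these compounds.

Measured so far in a physicochemical assay for solubility, in phosphate buffer, measured as thermodynamic solubility, at pH 7.4; on this read-out lower numbers stand for lower solubility and higher numbers for higher solubility:
compound 1 `CS(=O)(=O)NC(=O)CCc1cn(-c2ccc(F)cc2)nc1-c1ccc(Cl)cc1`: 25000 nM
compound 2 `CS(=O)(=O)NC(=O)CCc1cn(-c2ccc(Br)cc2)nc1-c1ccccc1`: 200000 nM
compound 3 `CS(=O)(=O)NC(=O)CCc1cn(-c2ccc(Cl)cc2)nc1-c1ccccc1Cl`: 90000 nM

On these three numbers compound 2 stands highest in this assay. Its nearest neighbour is compound 3, whose number is lower by a margin beyond the scatter; compound 1 lies furthest below, again beyond the scatter. For the measured compounds named here, no pair among the three differs in one place only, so no single-point step is available, and the spread can only be read as what the three values show side by side.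

Compound 4 `CS(=O)(=O)NC(=O)CCc1cn(-c2ccc(Br)cc2)nc1Cc1ccccc1` is not yet measured. Against compound 2 it carries benzyl in place of phenyl on an aromatic carbon. Going by the values given here, nothing among the measured compounds tests a benzyl in place of a phenyl on an aromatic carbon, so there is no directly comparable step to lean on. The expectation is therefore kept close to the starting point: no step beyond the scatter is expected from compound 2 to compound 4 in this assay, with the estimated step of a 1.5-fold lower number from compound 2 to compound 4 (0.19 log units; within the scatter) and a wide margin on either side. For compound 4 the estimate in this assay is 130000 nM, within 40000 nM to 350000 nM.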

Compound 4, solubility: 200000 nM
Compound 4: the middle estimate sits 1.5-fold (0.19 log units) below what was measured; the measured number falls inside the stated range.
By their numbers in this assay, from the lowest: compound 1; then compound 3; then compounds 2 and 4 (each within the scatter of the next).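

In this assay, for the compounds shown here, this is the first single-point step: benzyl in place of phenyl on the aromatic carbon next to the ring nitrogen gives no change at the digits printed from compound 2 to compound 4 (within the scatter). With the 4-bromophenyl group and the 2-((methylsulfonyl)carbamoyl)ethyl group held constant, this position therefore takes benzyl, with 7 heavy atoms against 6 for phenyl, without a step beyond the scatter, so this single change leaves the read-out where it was. No measurement at hand bears on what lies behind this result.

On these data alone, one step at one position cannot show how far this tolerance extends, and it remains open whether a longer chain such as phenethyl, or an amine such as morpholine, at this aromatic carbon would also leave this assay within the scatter. As far as these compounds go, it is equally open whether benzyl in place of phenyl would give the same result on the halogen-substituted aryl patterns of compound 1 and compound 3, or whether a carboxylic acid in place of the methylsulfonyl amide end of the chain would move the number further than this change did.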